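Benzylamino nucleoside series: methoxy to trifluoromethyl

This account rests on a few compounds, and the source may have more. Where it says the series, first, only, none or still open, it means among the compounds named here.

Three measured compounds share one core. Compound 1 `OC[C@H]1O[C@@H](n2cnc3c(NCc4ccc(Br)cc4)ncnc32)[C@H](O)[C@@H]1O` carries a 4-bromophenyl group; in a functional assay on HOS cells (Homo sapiens) for antiproliferative activity, with a stated time of 72 h (on this read-out lower numbers stand for stronger inhibition and higher numbers for weaker inhibition), compound 1 gives > 166000 nM, which is a limit of the assay and not a number. Compound 2 `COc1cccc(CNc2ncnc3c2ncn3[C@@H]2O[C@H](CO)[C@@H](O)[C@H]2O)c1` carries a 3-methoxyphenyl group; in this assay compound 2 gives > 166000 nM, again a limit of the assay. Compound 3 `OC[C@H]1O[C@@H](n2cnc3c(NCc4ccccc4C(F)(F)F)ncnc32)C(O)C1O` carries a trifluoromethyl-bearing phenyl group; in this assay compound 3 gives > 166000 nM, also a limit of the assay.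

Compound 2 thus stands at the limit, as does every value shown (the limit of > 166000 nM in this assay, at which 3 of the 3 values shown sit). Among the compounds with values here, the single step between measured compounds, a step that the two limits leave unreadable from compound 1 to compound 2, cannot be read.

Compound 4 `OC[C@H]1O[C@@H](n2cnc3c(NCc4cccc(C(F)(F)F)c4)ncnc32)[C@H](O)[C@@H]1O` differs from compound 2 by trifluoromethyl in place of methoxy on an aromatic carbon. Within the data shown here, no measured step bears directly on this change, and with all values at the limit of > 166000 nM in this assay, at which 3 of the 3 values shown sit, nothing points to a move beyond the scatter. Compound 4 is expected to remain at the limit, with an estimated step that the limit leaves unreadable from compound 2 to compound 4. The estimate for compound 4 is 250000 nM, within 60000 nM to 1000000 nM.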

Compound 4, half-maximal inhibitory concentration: > 166000 nM
Compound 4: a limit, no number (the forecaster's own chance of this, stated with the estimate: 85%); the middle value is on the limit's open side.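

Compound 4 also ends at a limit of the assay and not a number, so no new step to it from compound 1 or compound 2 can be read: the limit of > 166000 nM in this assay, at which 4 of the 4 values shown sit.

The compounds shown leave open whether any phenyl group on the shared core gives a readable value in this assay.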